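Urea analogues: trifluoromethyl in place of trifluoromethoxy

The source may report more compounds than this note shows. Statements on the series, on what has been measured and on what is new or still open speak of the compounds shown alone.

Measured compounds:
- compound 1, `CC1(C)CC(C)(C)c2cc(NC(=O)Nc3ccc(OC(F)(F)F)cc3)ccc2O1`: 91.5%
- compound 2, `CCC1(CC)CC(C)(C)Oc2ccc(NC(=S)Nc3ccc(C(F)(F)F)cc3)cc21`: 11.8%
- compound 3, `CC1(C)CC(C)(C)c2cc(NC(=S)Nc3ccc(C(F)(F)F)cc3)ccc2O1`: 2%

Of the compounds shown here, three have been tested in a functional assay on A2780 cells (Homo sapiens) for inhibition, with a stated time of 72 h, tested at 10 uM; on this read-out higher numbers stand for more inhibition of growth at the one concentration tested and lower numbers for less inhibition of growth. Compound 1 stands highest of the three; in this assay compound 1 gives 91.5%. The nearest of the others is compound 2, which gives 11.8%, a gap beyond the scatter. The furthest is compound 3, which gives 2%, also beyond the scatter. Among the measured compounds shown here, compounds 2 and 3 each differ from compound 1 in more than one place, so no single step between measured compounds is available, and their low numbers cannot be tied to any one feature.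

Compound 4, `CC1(C)CC(C)(C)c2cc(NC(=O)Nc3ccc(C(F)(F)F)cc3)ccc2O1`, has not yet been measured. It differs from compound 1 in one place: trifluoromethyl in place of trifluoromethoxy on an aromatic carbon. For the measured compounds named here, the only measured compounds carrying a trifluoromethyl group are compounds 2 and 3, and both are weak; whether the trifluoromethyl group or the other difference accounts for that cannot be told from these three numbers. Since the change is small in size, compound 1 is the best guide, but the weak trifluoromethyl compounds argue for caution. A downward step of moderate size is expected, a number 31.5 percentage points lower from compound 1 to compound 4 (beyond the scatter), with a wide range. For compound 4 the estimate in this assay is 60%, between 15% and 90%.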

Compound 4, percent growth inhibition at one concentration: 88.4%
Compound 4: middle estimate off by 28.4 percentage points, on the low side; low and high end bracket the measured number.
By their numbers in this assay, from the lowest: compounds 3 and 2 (each within the scatter of the next); then compounds 4 and 1 (each within the scatter of the next).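

In this assay, putting trifluoromethyl in place of trifluoromethoxy on this aromatic carbon, para to a large group, gives a number 3.1 percentage points lower from compound 1 to compound 4 (within the scatter), so with the rest of the molecule held constant, this position accepts either group with no readable difference at the one concentration tested. This also separates the trifluoromethyl group from the weak results seen earlier: compound 4 carries it and gives 88.4%, whereas compound 3 carries it too and gives only 2%, so the group does not by itself go with a low number, and compound 3 is the exception that shows it can still occur in a weak compound. No measurement available here gives a reason why the two groups behave alike.

On these data alone, it remains open how far this tolerance extends, for instance whether an amine, a carboxylic acid or a longer alkyl chain on the same carbon would keep growth inhibition at this level. A single-concentration reading also leaves open whether compound 1 and compound 4 would still match at lower concentrations.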